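This account rests on a few compounds, and the source may have more. Where it says the series, first, only, none or still open, it means among the compounds named here.

Of the compounds shown here, three have so far been tested in an in vitro ADME assay on microsomes from liver (Homo sapiens) for metabolic stability; on this read-out lower numbers stand for slow clearance and higher numbers for fast clearance. Compound 1 `OC1CCCC(c2n[nH]cc2-c2ccnc(NC3CCCC3)n2)C1` gives 0.015 mL/min/kg and compound 3 `CC(C)Nc1nccc(-c2c[nH]nc2C2CCN(S(C)(=O)=O)CC2)n1` gives 0.012 mL/min/kg in this assay, while compound 2 `CC(C)Nc1nccc(-c2c[nH]nc2-c2ccc(Cl)cc2)n1` gives 0.106 mL/min/kg, the highest of the three readings, well beyond the scatter above compound 1 and further still above compound 3. Compound 4 `CC(C)Nc1nccc(-c2c[nH]nc2C2CCCNC2)n1` has not yet been measured. It differs from compound 2 in one place: piperidin-3-yl in place of 4-chlorophenyl on an aromatic carbon. Both compounds without a 4-chlorophenyl, compound 1 and compound 3, give low readings, so a clear fall in clearance is expected for compound 4, with the estimated step of a 4.2-fold lower number from compound 2 to compound 4 (0.63 log units; beyond the scatter). Compound 4 is therefore estimated at 0.025 mL/min/kg, with a likely range from 0.008 mL/min/kg to 0.08 mL/min/kg.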

Compound 4, clearance: 0.014 mL/min/kg
For compound 4 the middle estimate is 1.8-fold (0.25 log units) above the measured one, within the range that was stated.
By their numbers in this assay, from the lowest: compounds 3, 4 and 1 (each within the scatter of the next); then compound 2.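

Replacing 4-chlorophenyl with piperidin-3-yl on this aromatic carbon gives a 7.6-fold lower number from compound 2 to compound 4 (0.88 log units; beyond the scatter) in this assay. Within the data shown here, no earlier pair of measured compounds differed in one place only, so this is the first reading of a single change at this position. Nothing measured here gives a reason for the fall. The compounds shown leave open whether the fall goes with losing the chlorine, losing the aromatic ring or gaining the ring nitrogen. Plain phenyl and cyclohexyl at this position would help separate these three changes.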